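Aryl Triazole Swap in a Spirooxindole Quinoxaline Series

The compounds below may be only part of what the source reports. "The series", "measured", "known", "first", "only" and "open" are said of these compounds alone.

Compound 1, `N#CC1=C(N)Oc2c(c3nc4ccccc4nc3c3ccccc23)C12C(=O)N(Cc1cnnn1-c1ccccc1Br)c1ccccc12`: in a functional assay on HCT-116 cells (Homo sapiens) for antiproliferative activity, read by MTT assay, with a stated time of 48 h (on this read-out higher numbers stand for weaker inhibition and lower numbers for stronger inhibition), compound 1 gives > 50000 nM, which is a limit of the assay.
Compound 2, `N#CC1=C(N)Oc2c(c3nc4ccccc4nc3c3ccccc23)C12C(=O)N(Cc1cnnn1-c1ccc(F)c(Cl)c1)c1ccccc12`: in this assay compound 2 gives > 50000 nM, which is a limit of the assay.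
Compound 3, `Cc1cccc(-n2nncc2CN2C(=O)C3(C(C#N)=C(N)Oc4c(N)cc5nc6ccccc6nc5c43)c3ccccc32)c1`: in this assay compound 3 gives > 50000 nM, which is a limit of the assay.

Compound 3 therefore stands only at a limit in this assay, and the other two values shown are limits as well, so no order among the three can be read. Among the measured compounds shown here, the one measured step, a step that the two limits leave unreadable from compound 1 to compound 2, cannot be sized from its two limits. Compound 4, `COc1ccc(-n2nncc2CN2C(=O)C3(C(C#N)=C(N)Oc4c(N)cc5nc6ccccc6nc5c43)c3ccccc32)cc1`, differs from compound 3 by 4-methoxyphenyl in place of 3-methylphenyl on an aromatic nitrogen. For the measured compounds named here, no measured step bears on this change, and because every value shown sits at the limit (the limit of > 50000 nM in this assay, at which 3 of the 3 values shown sit), the expectation is that compound 4 will also be reported as a limit in this assay. Compound 4 is thus expected near 50000 nM, within 20000 nM to 120000 nM, and the expected step is a number no higher from compound 3 to compound 4 (the limit leaves the size open).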

Compound 4, half-maximal inhibitory concentration: > 50000 nM
Compound 4 gave a limit, no number; the forecaster's own chance of this, stated with the estimate: 80%; the middle value sits exactly at the limit.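

In this assay compound 4 gives > 50000 nM, a limit and not a number, so no step can be read between compound 3 and compound 4. The compounds shown leave open what any of these aryl changes does to the read-out, since no value is a number: the limit of > 50000 nM in this assay, at which 4 of the 4 values shown sit.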